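A few compounds are considered here, and "the series" means these few. Any claim that something is new, unique, unknown or untested is made for them only; others in the source may bear on it.

Measured so far in an ADME assay on CCRF-HSB-2 cells (Homo sapiens) for cytotoxicity, with a stated time of 7 days; a higher number here means that more compound is tolerated, a lower number that less compound is tolerated:

- Compound 1, `CCOc1nc(N)nc2c1ncn2/C=C1/CC1(CO)CO`. In this assay compound 1 gives > 20000 nM, which is a limit of the assay rather than a number.
- Compound 2, `CCCNc1nc(N)nc2c1ncn2/C=C1/CC1(CO)CO`. In this assay compound 2 gives > 20000 nM, again a limit and not a number.
- Compound 3, `CCCCCCCCSc1nc(N)nc2c1ncn2/C=C1/CC1(CO)CO`. In this assay compound 3 gives 60000 nM.

Compound 1 therefore stands at a limit, so its exact place on the scale is not known, and the same holds for one of the other two values: the limit of > 20000 nM in this assay, at which 2 of the 3 values shown sit. The measured steps are a step that the two limits leave unreadable from compound 1 to compound 2, a step that the limit leaves unreadable from compound 1 to compound 3 and a step that the limit leaves unreadable from compound 2 to compound 3; none of them has a readable size, since the limit hides where the values lie. What the three values do show is that every measured compound is tolerated by the cells at high concentration.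

Compound 4 is `Nc1nc(NC2CCCCC2)c2ncn(/C=C3/CC3(CO)CO)c2n1`. It differs from compound 1 in one place: cyclohexylamino in place of ethoxy on an aromatic carbon. All three measured changes at this position leave the cells tolerating the compound, so no step beyond the scatter is expected in this assay, and the result for compound 4 is expected to be a limit again, a step that the limit leaves unreadable from compound 1 to compound 4. The estimate for compound 4 is 50000 nM, expected to fall between 15000 nM and 200000 nM.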

Compound 4, half-maximal cytotoxic concentration: > 20000 nM
Compound 4: no number, only a limit (the forecaster's own chance of this, stated with the estimate: 70%); the middle value lies beyond the limit too.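

In this assay compound 4 gives > 20000 nM, a limit and not a number, so its steps from compound 1, compound 2 and compound 3 cannot be read. How much the group at this position changes tolerance stays open, because most values sit at one limit: the limit of > 20000 nM in this assay, at which 3 of the 4 values shown sit.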